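This account rests on a few compounds, and the source may have more. Where it says the series, first, only, none or still open, it means among the compounds named here.

Measured in an assay for inhibition of Fatty-acid amide hydrolase 1 (Rattus norvegicus); on this read-out lower numbers stand for stronger inhibition and higher numbers for weaker inhibition:
compound 1 `O=C(CCCCC#Cc1cccnc1)c1ncc(-c2ccccn2)o1` gives 300 nM
compound 2 `COC(=O)c1ccc(CCCCCCC(=O)c2ncc(-c3ccccn3)o2)cc1` gives 1.5 nM
compound 3 `CC(C)(C)OC(=O)Nc1cccc(CCCCCCC(=O)c2ncc(-c3ccccn3)o2)c1` gives 2.4 nM

Compound 2 carries the lowest number of the three. Its gap to compound 3 lies within the scatter, so these two cannot be ordered; compound 1 lies far beyond the scatter from both.

Compound 4 `CC(C)(C)OC(=O)Nc1ccc(CCCCCCC(=O)c2ncc(-c3ccccn3)o2)cc1` is not yet measured. It differs from compound 2 in one place: (tert-butoxycarbonyl)amino in place of methoxycarbonyl on an aromatic carbon. Among the compounds with values here, no pair of measured compounds isolates this exchange. Compound 3 carries the same entering group on the same ring, and its value of 2.4 nM sits within the scatter of compound 2, so little change is expected. The expected step is a 1.3-fold higher number from compound 2 to compound 4 (0.12 log units; within the scatter), none beyond the scatter. Compound 4 is estimated at 2 nM, range 0.7 nM to 6 nM.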

Compound 4, inhibition constant: 5.6 nM
Compound 4: the middle estimate sits 2.8-fold (0.45 log units) below what was measured; the measured number falls inside the stated range.
By their numbers in this assay, from the lowest: compounds 2 and 3 (each within the scatter of the next); then compound 4; then compound 1.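

Within the data shown here, the exchange of methoxycarbonyl for (tert-butoxycarbonyl)amino, on an aromatic carbon para to a large group, gives the first single-place step: a 3.7-fold higher number from compound 2 to compound 4 (0.57 log units; beyond the scatter) in this assay. This position therefore tolerates the larger entering group, but not without a modest cost that lies beyond the scatter. Nothing available accounts for this step.

The compounds shown leave open whether the step follows the tert-butyl end or the amino link. A free amine or a carboxylic acid at this position would help separate the two.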